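Benzyloxy for 1-phenylethyl on the carbonyl carbon

The source may report more compounds than this note shows. Statements on the series, on what has been measured and on what is new or still open speak of the compounds shown alone.

For the measured compounds named here, in a functional assay on A2780 cells (Homo sapiens) for cytotoxicity (a lower number here means a stronger inhibitor, a higher number a weaker inhibitor), compound 1 (`CC(C)(C)C(=O)Nc1ncc(SCc2ncc(C(C)(C)C)o2)s1`) gives 250 nM and compound 2 (`C[C@@H](C(=O)Nc1ncc(SCc2ncc(C(C)(C)C)o2)s1)c1ccccc1`) gives 900 nM as the higher of the two numbers so far. Going by the values given here, only one measured step bears on the next change, and it also falls on a carbonyl carbon (a 3.6-fold higher number from compound 1 to compound 2 (0.56 log units; beyond the scatter)). Compound 3 (`CC(C)(C)c1cnc(CSc2cnc(NC(=O)OCc3ccccc3)s2)o1`) carries benzyloxy in place of 1-phenylethyl on the carbonyl carbon whose other neighbour is an amide-type nitrogen (benzyloxy in place of 1-phenylethyl on a carbonyl carbon). The six-membered aromatic ring stays in this swap and the defined stereocentre leaves, whereas the measured step replaced tert-butyl and brought that ring in. A smaller step is therefore expected, within the scatter and with no firm direction. The expected change is small (a 1.3-fold lower number from compound 2 to compound 3 (0.11 log units; within the scatter)). Compound 3 is estimated at 700 nM (expected range 230 nM to 2100 nM).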

Compound 3, half-maximal inhibitory concentration: 1040 nM
Compound 3: middle estimate off by 1.5-fold (0.17 log units), on the low side; the measured number falls inside the stated range.
By their numbers in this assay, from the lowest: compound 1; then compounds 2 and 3 (each within the scatter of the next).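

In this assay the swap of 1-phenylethyl for benzyloxy on the carbonyl carbon gives a 1.2-fold higher number from compound 2 to compound 3 (0.06 log units; within the scatter) and so does not separate these two groups, even though the defined stereocentre leaves and a hydrogen-bond acceptor enters. Set against tert-butyl, benzyloxy gives a 4.2-fold higher number from compound 1 to compound 3 (0.62 log units; beyond the scatter) as a step beyond the scatter. Both compounds with a six-membered aromatic ring in this group therefore stand above compound 1, and none of the three compounds goes against this.

Going by these compounds, it remains open whether a small amine such as dimethylamino, or a short chain such as methyl, on this carbonyl carbon would fall with compound 1 or with compounds 2 and 3. No measurement at hand accounts for these numbers.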